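A Carbamoyl Swap at the Assay Limit

A few compounds are considered here, and "the series" means these few. Any claim that something is new, unique, unknown or untested is made for them only; others in the source may bear on it.

In a functional assay on NCI-H460 cells (Homo sapiens) for inhibition, read by MTT assay, with a stated time of 4 days (on this read-out lower numbers stand for stronger inhibition and higher numbers for weaker inhibition), compound 1 (`COc1cc(NC(C)CCCNC(=O)NN)c2ncccc2c1`) reads > 100000 nM as a limit of the assay and not a number. Compound 2 (`COc1cc(NC(C)CCCNC(=O)NNC(=O)NCCO)c2ncccc2c1`) reads > 100000 nM as a limit too. Compound 3 (`COc1cc(NC(C)CCCNC(=O)NNC(=O)NC(CO)(CO)CO)c2ncccc2c1`) likewise reads > 100000 nM as a limit. Compound 3 therefore stands at the limit of > 100000 nM in this assay, at which 3 of the 3 values shown sit, and gives no number to build on.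

Compound 4 (`COc1cc(NC(C)CCCNC(=O)NNC(=O)N(CCO)CCO)c2ncccc2c1`) has not yet been measured. Its difference from compound 3 is bis(2-hydroxyethyl)amino in place of (2-hydroxy-1,1-bis(hydroxymethyl)ethyl)amino on a carbonyl carbon and it amounts to bis(2-hydroxyethyl)amino in place of (2-hydroxy-1,1-bis(hydroxymethyl)ethyl)amino on a carbonyl carbon.

The closest measured change is a step that the two limits leave unreadable from compound 2 to compound 3 and it also alters the group at the end of the chain. The other two changes are a step that the two limits leave unreadable from compound 1 to compound 2 and a step that the two limits leave unreadable from compound 1 to compound 3 and neither of them gives a size either. With no readable step to draw on, no shift beyond the scatter is expected in this assay and no direction is favoured. The expected outcome is a number no higher from compound 3 to compound 4 (the limit leaves the size open) and no more. Compound 4 is estimated at 100000 nM with an expected range from 40000 nM to 200000 nM and will most likely be reported only as a limit.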

Compound 4, half-maximal inhibitory concentration: > 100000 nM
Compound 4 gave a limit, no number; the forecaster's own chance of this, stated with the estimate: 90%; the middle value lies on the limit itself.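

In this assay compound 4 gives a limit and not a number, as do compound 1, compound 2 and compound 3, so no new step can be read: the limit of > 100000 nM in this assay, at which 4 of the 4 values shown sit. The compounds shown leave open how strongly any of them inhibits in this assay and whether the group on the carbonyl carbon changes that at all.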